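Methyl to Ethyl on the Phenyl Ring, a Small Step

The source may hold more compounds than are shown below. What is called first, only, known or untested is meant among the compounds shown, and "the series" means these compounds.

Compound 1 `C=CC(=O)Nc1cccc(NC(=O)CSc2nc(Nc3cccc(Cl)c3)c3ccccc3n2)c1` gives 9460 nM in a functional assay on NCI-H1975 cells (Homo sapiens) for inhibition, read by MTT assay, with a stated time of 72 h; a higher number here means a weaker inhibitor, a lower number a stronger inhibitor.
Compound 2 `C=CC(=O)Nc1cccc(NC(=O)CSc2nc(Nc3cccc(C)c3)c3ccccc3n2)c1` gives 12100 nM in this assay.

Going by the values given here, compound 2 has the higher of the two numbers so far, but the step of a 1.3-fold higher number from compound 1 to compound 2 (0.11 log units; within the scatter) is within the scatter, so the two compounds cannot be told apart. Compound 3 `C=CC(=O)Nc1cccc(NC(=O)CSc2nc(Nc3ccc(CC)cc3)c3ccccc3n2)c1` is not yet measured. It differs from compound 2 by 4-ethylphenyl in place of 3-methylphenyl on a nitrogen on an aromatic ring. Among the compounds with values here, no measured step tests a change of this kind: the only known step, from compound 1 to compound 2, exchanged one small group for another and stayed within the scatter. On that basis the change to compound 3 is expected to move this assay little, if at all, and the expected step is a 1.0-fold lower number from compound 2 to compound 3 (0.00 log units; within the scatter). Compound 3 is therefore estimated at 12000 nM, with a range from 5000 nM to 30000 nM.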

Compound 3, half-maximal inhibitory concentration: 8270 nM
Compound 3: the middle estimate sits 1.5-fold (0.16 log units) above what was measured; measured number inside the range.
By their numbers in this assay, from the lowest: compounds 3, 1 and 2 (each within the scatter of the next).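

In this assay, the group on the nitrogen on an aromatic ring was changed more fully than before, yet the new steps (a 1.5-fold lower number from compound 2 to compound 3 (0.17 log units; within the scatter) and a 1.1-fold lower number from compound 1 to compound 3 (0.06 log units; within the scatter)) leave compound 3 indistinguishable from both earlier compounds. The first step showed only that methyl and chloro could not be told apart, whereas these steps show the same result for 4-ethylphenyl, which differs from 3-methylphenyl in both the chain and its printed ring position. No supporting measurement bears on this result.

Because the chain and its ring position change together here, the compounds shown cannot separate the contribution of either one. Going by these compounds, whether a phenyl ring carrying an amine, a carboxylic acid or a longer chain such as butyl would give a step beyond the scatter also remains open.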